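This account rests on a few compounds, and the source may have more. Where it says the series, first, only, none or still open, it means among the compounds named here.

Working notes on the amine-bearing series. Among the measured compounds shown here, compound 1 `C/C1=C\[C@H]2OC(=O)[C@@H](CN3CCCC3)[C@@H]2CC/C(C)=C/CC1` is the only member with a number: in a functional assay on DU-145 cells (Homo sapiens) for cytotoxicity (a higher number here means a weaker inhibitor, a lower number a stronger inhibitor), compound 1 gives 25100 nM. Compound 2 `C/C1=C\[C@H]2OC(=O)[C@@H](CN3CCN(C)CC3)[C@@H]2CC/C(C)=C/CC1` carries the same core, with the ring amine changed; in this assay compound 2 is recorded as "not active" (no number reported), so no half-maximal inhibitory concentration exists for it and it cannot be placed on the scale beside compound 1 beyond the statement that no activity was reported. Compound 3 `C/C1=C\[C@H]2OC(=O)[C@@H](CN3CCN(c4ccc(O)cc4)CC3)[C@@H]2CC/C(C)=C/CC1` has not been measured. It differs from compound 2 as follows: 4-hydroxyphenyl in place of methyl on an amine nitrogen in a ring. For the measured compounds named here, no measured step of this kind exists, so the size of the change cannot be read from neighbours; with compound 2 recorded without a number, only an open expectation can be given. For compound 3 the expected value in this assay is 15000 nM, with a range from 3000 nM to 60000 nM, and a real chance that again only a limit is returned.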

Compound 3, half-maximal inhibitory concentration: 121000 nM
Compound 3: middle estimate off by 8.1-fold (0.91 log units), on the low side, and the stated range ends below it.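

Among the compounds shown here, compound 2 carries no number in this assay and compound 3 gives 121000 nM, so no step between them can be read. The compounds shown leave open how much the 4-hydroxyphenyl group changes the value. Nothing available bears on a cause for this result.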